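From Amino to Fluoro on the Shared Core

The source may report more compounds than this note shows. Statements on the series, on what has been measured and on what is new or still open speak of the compounds shown alone.

Two compounds with a shared core have been taken into a functional assay on T47D cells (Homo sapiens) for cytotoxicity, read by MTT assay; on this read-out lower numbers stand for stronger inhibition and higher numbers for weaker inhibition. Going by the values given here, in this test, compound 1 (`COc1cc(O)ccc1/C=C/C(=O)c1ccc(NC(C)=O)cc1`) gives 12300 nM, the only number available so far. Compound 2 (`COc1cc(O)ccc1/C=C/C(=O)c1ccc(N)cc1`) carries an amino group on the same core, and the result for compound 2 stands as "not determined" (no result reported). Compound 2 therefore has no place on the numerical scale, and it cannot be ranked against compound 1.

The next compound, compound 3 (`COc1cc(O)ccc1/C=C/C(=O)c1ccc(F)cc1`), differs from compound 2 in a single place: fluoro in place of amino on an aromatic carbon. Among the compounds with values here, no measured pair shows what a change at this place does in this assay. The expectation is therefore of no step beyond the usual scatter in either direction, taking compound 1 at 12300 nM as the only reference point. For compound 3 the estimated value is 10000 nM, with an expected range from 3000 nM to 35000 nM.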

Compound 3, half-maximal inhibitory concentration: 8510 nM
For compound 3 the middle estimate is 1.2-fold (0.07 log units) above the measured one; the measured number falls inside the stated range.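

In this assay the place para to a large group now has its first readable step: fluoro in place of acetamido on an aromatic carbon gives a 1.4-fold lower number from compound 1 to compound 3 (0.16 log units; within the scatter) and so no change beyond the scatter. At this place the test therefore does not tell these two groups apart, although they differ widely in name and kind, and the shared core keeps its read-out with either of them. The step from the amino group of compound 2 cannot be read, since compound 2 has no number, and nothing measured here offers an explanation for the result.

What the compounds shown leave open is whether any group at this place moves the number beyond the scatter, for instance a chlorine atom, a methoxy group, a carboxylic acid or a longer amide chain in place of the acetamido group. They also leave open how the free amino group of compound 2 compares with the fluoro and acetamido groups in this test.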